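Trifluoromethoxy added to a weak cell-growth inhibitor series

This account rests on a few compounds, and the source may have more. Where it says the series, first, only, none or still open, it means among the compounds named here.

Of the compounds shown here, three from one family have been tested in a functional assay on Huh-7 cells (Homo sapiens) for inhibition, read by sulforhodamine B assay, with a stated time of 72 h (a higher number here means a weaker inhibitor, a lower number a stronger inhibitor), a measurement of how well each compound stops the growth of a liver-derived cancer cell line. Compound 2, with structure `CC(c1ccc(-c2ccccc2)c(F)c1)c1nnc2n1N=C(c1ccccc1)CS2`, gives 6700 nM. Compound 1, with structure `CC(c1ccc(-c2ccccc2)c(F)c1)c1nnc2n1N=C(c1ccc(OC(F)(F)F)cc1)CS2`, gives 8400 nM. Compound 3, with structure `CC(C)Cc1ccc(C(C)c2nnc3n2N=C(c2ccccc2)CS3)cc1`, gives 6100 nM. All three sit close together, and none of the gaps between them is larger than the ordinary noise of repeated measurements.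

Compounds 2 and 1 are related by a single change: trifluoromethoxy in place of hydrogen on an aromatic carbon. That change made a step of a 1.3-fold higher number from compound 2 to compound 1 (0.10 log units; within the scatter) in this assay, a step small enough to be indistinguishable from noise.

Compound 4, with structure `CC(C)Cc1ccc(C(C)c2nnc3n2N=C(c2ccc(OC(F)(F)F)cc2)CS3)cc1`, has not yet been measured. It is built from compound 3 by the same change: trifluoromethoxy in place of hydrogen on an aromatic carbon. The surroundings of the change, described as the carbon of a six-membered aromatic ring bearing only carbon, para to a large group, are identical in both pairs. The two cores, that of compound 3 and that of compound 2, do differ, but that difference is not broken down here.

Because the earlier step of a 1.3-fold higher number from compound 2 to compound 1 (0.10 log units; within the scatter) was within the usual scatter, the expected step from compound 3 to compound 4 is likewise small, estimated as a 1.3-fold higher number from compound 3 to compound 4 (0.11 log units; within the scatter) in this assay. Compound 4 is therefore expected to give about 7900 nM, with a likely spread from 4000 nM to 16000 nM. Since this expectation rests on one prior example in a different core, it should be held loosely.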

Compound 4, half-maximal inhibitory concentration: 3600 nM
Estimate against measurement, compound 4: 2.2-fold (0.34 log units) above; measured number below the stated range.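

In this assay, trifluoromethoxy in place of hydrogen on an aromatic carbon gave a 1.7-fold lower number from compound 3 to compound 4 (0.23 log units; within the scatter), so this step, like the earlier one, cannot be told apart from the ordinary noise of repeated measurements. Set side by side, the two steps differ by no more than the noise of two such steps would allow: the same change on two cores in this assay, a 1.3-fold higher number (0.10 log units; within the scatter) from compound 2 to compound 1 and a 1.7-fold lower number (0.23 log units; within the scatter) from compound 3 to compound 4, 2.1-fold (0.33 log units) apart, within the scatter of two such steps. This shows that on these two cores the change produced no step beyond the scatter, and that nothing here separates its effect on one core from its effect on the other; it does not show that the change has no effect at all or that its effect is identical on both cores, as two pairs are a small base and a small real difference could lie hidden in the scatter.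

The compounds shown leave open whether an amine, a carboxylic acid or a methoxy group on the same aromatic carbon would give a step beyond the scatter. They also leave open whether the two pairs would stay as close together in any test other than this assay.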